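The source may hold more compounds than are shown below. What is called first, only, known or untested is meant among the compounds shown, and "the series" means these compounds.

Of the compounds shown here, three sharing one core have been measured in a functional assay on HeLa cells (Homo sapiens) for inhibition, read by sulforhodamine B assay; on this read-out lower numbers stand for stronger inhibition and higher numbers for weaker inhibition. Compound 1 `O=C1C(Nc2ccc(I)cc2)=CC(=O)c2c1nc1n2[C@H]2OC[C@@H](O)[C@H]2OC1` gives 4010 nM, compound 2 `O=C1C=C(Nc2cccc(F)c2)C(=O)c2c1nc1n2[C@H]2OC[C@@H](O)[C@H]2OC1` gives 6440 nM, and compound 3 `O=C1C=C(Nc2ccc(Br)cc2)C(=O)c2c1nc1n2[C@H]2OC[C@@H](O)[C@H]2OC1` gives 3830 nM. Compound 1 stands second highest of these three numbers, but its gaps to compound 3 and to compound 2 both lie within the scatter, so the three cannot be ordered. Going by the values given here, the step of a 1.7-fold lower number from compound 2 to compound 3 (0.23 log units; within the scatter) is the only measured step, and it swaps one aromatic ring for another on the amine nitrogen. Compound 4 `O=C1C(NCc2ccccc2)=CC(=O)c2c1nc1n2[C@H]2OC[C@@H](O)[C@H]2OC1` differs from compound 1 by benzyl in place of 4-iodophenyl on an amine nitrogen. No measured step exchanges an aromatic group for a benzyl group on this nitrogen, so nothing shown speaks for a step beyond the scatter, and the expected step of a 1.2-fold higher number from compound 1 to compound 4 (0.10 log units; within the scatter) is small. Compound 4 is therefore estimated at 5000 nM, with a range from 1500 nM to 16000 nM.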

Compound 4, half-maximal inhibitory concentration: 11000 nM
Beside the measured number, compound 4's estimate is 2.2-fold (0.34 log units) below it; measured number inside the range.
By their numbers in this assay, from the lowest: compounds 3, 1, 2 and 4 (each within the scatter of the next, the first and the last beyond it).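

Putting benzyl in place of 4-iodophenyl on this amine nitrogen in this assay gives a 2.7-fold higher number from compound 1 to compound 4 (0.44 log units; beyond the scatter), the first step among these compounds to pass beyond the scatter, so the group here can change the result. The two groups have the same heavy-atom count and one aromatic ring each, yet they differ in both the iodine and the carbon linking the ring to the nitrogen. No available evidence explains the step.

Which difference matters remains open. A 4-iodobenzyl or plain phenyl group on this nitrogen would help separate them.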